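Adding 2-aminophenyl to compound 2

The source may hold more compounds than are shown below. What is called first, only, known or untested is meant among the compounds shown, and "the series" means these compounds.

Compound 1 `COc1cc2ncn([C@@H]3O[C@H](CO)[C@@H](O)[C@H]3O)c2cc1OC` – > 100000 nM (a limit)
Compound 2 `Cn1c(C(F)(F)F)nc2cc(Cl)c(Cl)cc21` – 56000 nM

Among the measured compounds shown here, in a functional assay on HCT-116 cells (Homo sapiens) for cytotoxicity, read by MTT assay, with a stated time of 48 h (on this read-out higher numbers stand for weaker inhibition of growth and lower numbers for stronger inhibition of growth), compound 2 holds the only actual number, 56000 nM (no other compound has one to set it against). For compound 1 this assay gives only a limit (> 100000 nM). Compound 3 `Nc1ccccc1Cn1c(C(F)(F)F)nc2cc(Cl)c(Cl)cc21` has 2-aminophenyl in place of hydrogen on a saturated chain carbon bound to an aromatic nitrogen. For the measured compounds named here, no measured pair shows the effect of such a change, so only a moderate shift towards stronger inhibition of growth is expected, with a 3.7-fold lower number from compound 2 to compound 3 (0.57 log units; beyond the scatter) as the estimated step. Compound 3 is estimated at 15000 nM (expected range 3000 nM to 60000 nM).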

Compound 3, concentration for 50% growth inhibition: 26100 nM
Compound 3: middle estimate off by 1.7-fold (0.24 log units), on the low side, and the stated range covers the measured number.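

In this assay the saturated chain carbon bound to an aromatic nitrogen proves able to carry 2-aminophenyl in place of hydrogen, and the change gives a 2.1-fold lower number from compound 2 to compound 3 (0.33 log units; beyond the scatter) as a modest gain in inhibition of growth. Among the compounds shown here, this is the first step that can be read here, since the earlier compounds offered no pair differing in one place. Nothing at hand accounts for the size of this step. Going by these compounds, whether the amine on the ring matters stays open, and plain phenyl or a carboxylic acid in its place could tell. The compounds shown also do not say how a longer chain would fare at this carbon.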